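The source may report more compounds than this note shows. Statements on the series, on what has been measured and on what is new or still open speak of the compounds shown alone.

For the measured compounds named here, the three compounds measured so far share a core and were compared in an ADME assay on HT-29 cells (Homo sapiens) for inhibition, read by MTT assay, with a stated time of 72 h; on this read-out higher numbers stand for weaker inhibition and lower numbers for stronger inhibition. Compound 1 `C=CC(=O)Nc1cccc(Nc2nc(N/N=C/c3ccc(F)cc3)ncc2Cl)c1` gives 6340 nM in this assay. Compound 2 `C=CC(=O)Nc1cccc(Nc2nc(N/N=C/c3ccccc3F)ncc2Cl)c1` gives 3500 nM. Compound 3 `C=CC(=O)Nc1cccc(Nc2nc(N/N=C(\C)c3ccc(F)cc3F)ncc2Cl)c1` gives 4360 nM; of the three numbers it stands second highest, nearest to compound 2 and furthest from compound 1, with both gaps inside the usual scatter of this assay. Compound 4 `C=CC(=O)Nc1cccc(Nc2nc(N/N=C(\C)c3ccc(C)cc3)ncc2Cl)c1` has not yet been measured. It differs from compound 3 in one place: 4-methylphenyl in place of 2,4-difluorophenyl on a carbon with a double bond to nitrogen. Going by the values given here, only one measured step changes a single place, a 1.8-fold lower number from compound 1 to compound 2 (0.26 log units; within the scatter), and it stayed within the scatter. Among the compounds with values here, no measured step removes fluorine from this ring or brings in a methyl group, so the change to compound 4 is not covered directly; the one step that bears on it shows that a change on this ring left the number where it was. Compound 4 is therefore expected to stay close to compound 3, with a step of a 1.0-fold higher number from compound 3 to compound 4 (0.01 log units; within the scatter) that is expected not to exceed the scatter. The estimate for compound 4 in this assay is 4500 nM, in a range from 1500 nM to 13000 nM.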

Compound 4, half-maximal inhibitory concentration: 3210 nM
For compound 4 the middle estimate is 1.4-fold (0.15 log units) above the measured one, and the stated range covers the measured number.
By their numbers in this assay, from the lowest: compounds 4, 2, 3 and 1 (each within the scatter of the next).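

In this assay, putting 4-methylphenyl in place of 2,4-difluorophenyl on a carbon with a double bond to nitrogen gives a 1.4-fold lower number from compound 3 to compound 4 (0.13 log units; within the scatter), so this position accepts a ring with no fluorine and with a methyl group without the number leaving the scatter, which the earlier step, a change in where a single fluorine sits, could not show. The wider changes on the nitrogen on an aromatic ring, which also bring in the saturated chain carbon, give a 1.1-fold lower number from compound 2 to compound 4 (0.04 log units; within the scatter) and a 2.0-fold lower number from compound 1 to compound 4 (0.30 log units; within the scatter), so all the steps to the new compound stay within the scatter, and the four compounds do not yet separate at this position. Nothing available on these compounds offers an account of these numbers.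

Going by these compounds, all four compounds carry a six-membered aromatic ring of carbon only with no hydrogen-bond donors or acceptors on it, so it remains open how the number would respond to an amine or a carboxylic acid on that ring, or to a longer chain in place of the saturated chain carbon. No single-place step isolates that saturated chain carbon either, as no pair shown keeps the ring the same while changing only that carbon.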